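From Bromo to Chloro: Estimating Compound 3

The source may report more compounds than this note shows. Statements on the series, on what has been measured and on what is new or still open speak of the compounds shown alone.

Of the compounds shown here, two have been measured in a functional assay on PC-12 cells (Rattus norvegicus) for cytotoxicity, read by MTT assay, with stated times of 3 h and 2 h, tested at 10 uM; a higher number here means a stronger effect of the compound at the concentration tested, a lower number a weaker effect. Compound 1 `O=C(CCCCC1CCSS1)NCc1cn(CCCCOc2ccc3cc(-c4ccccc4)c(=O)oc3c2)nn1` gives 30.5% in this assay, and compound 2 `O=C(CCCCC1CCSS1)NCc1cn(CCCCOc2ccc3cc(-c4ccc(Br)cc4)c(=O)oc3c2)nn1` gives 42.6%. Going by the values given here, compound 2 therefore stands highest of the two numbers, and the single measured step, a number 12.1 percentage points higher from compound 1 to compound 2 (beyond the scatter), is the only guide available. Compound 3 `O=C(CCCCC1CCSS1)NCc1cn(CCCCOc2ccc3cc(-c4ccc(Cl)cc4)c(=O)oc3c2)nn1` differs from compound 2 in one place: chloro in place of bromo on an aromatic carbon. Among the compounds with values here, no measured step swaps one halogen for another, so the bromo-for-hydrogen step bears on it only loosely, showing that a single change at this place can shift the read-out by a modest amount. A change from one halogen to a related one is expected to move the read-out less than that, so the expected step is a number 4.6 percentage points lower from compound 2 to compound 3 (within the scatter). Compound 3 is therefore estimated at 38%, with a range from 25% to 50%.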

Compound 3, a percentage reported as activity, at one concentration (the size of the read-out at that concentration, not a potency): 61.8%
The estimate for compound 3 lay 23.8 percentage points below the measured number; the measured number lies above the stated range.
By their numbers in this assay, from the lowest: compound 1; then compound 2; then compound 3.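

The swap from 4-bromophenyl to 4-chlorophenyl is not a minor exchange at this place: in this assay it gives a number 19.2 percentage points higher from compound 2 to compound 3 (beyond the scatter). Set against hydrogen on the same aromatic carbon, chloro gives a number 31.3 percentage points higher from compound 1 to compound 3 (beyond the scatter), so both halogens raise the number over hydrogen, yet the heavier halogen does not give the higher number. No measurement shown here explains why chloro and bromo differ in this way.

Going by these compounds, with only hydrogen, bromo and chloro at this place, it remains open whether fluoro, a methoxy group or an amine on the same carbon would give a higher or lower number. On these data alone, it is also open whether the gap between chloro and bromo would persist with a longer chain in another part of the molecule.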